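The source may hold more compounds than are shown below. What is called first, only, known or untested is meant among the compounds shown, and "the series" means these compounds.

Measured compounds:
Compound 1, `CNc1nc(NCCCN(C)C)c2sc(-c3ccc(-n4cccn4)cc3)cc2n1`: 18.4 uL/min
Compound 2, `CNc1nc(NCCCN(C)C)c2sc(-c3ccc(S(C)(=O)=O)cc3)cc2n1`: 15 uL/min

In an ADME assay (liver) for metabolic stability, with Liver microsome (Homo sapiens) as the target, read by LC-MS, using microsomes, tested at 1 uM (on this read-out higher numbers stand for fast clearance and lower numbers for slow clearance), compound 2 stands lowest of the two numbers, with compound 1 nearest at a 1.2-fold lower number from compound 1 to compound 2 (0.09 log units; within the scatter). Compound 3, `CNc1nc(NCCCN(C)C)c2sc(-c3ccc(C(F)(F)F)cc3)cc2n1`, is not yet measured; it differs from compound 2 by trifluoromethyl in place of methylsulfonyl on an aromatic carbon. Among the compounds with values here, the only measured step bears on it indirectly: swapping one group at the same aromatic carbon gave a 1.2-fold lower number from compound 1 to compound 2 (0.09 log units; within the scatter), a change within the scatter. Within the data shown here, no step shows what trifluoromethyl does here, so a step in this assay no larger than the scatter is expected, with a slight rise if any. Compound 3 is expected at 20 uL/min, range 10 uL/min to 40 uL/min, meaning an expected step of a 1.3-fold higher number from compound 2 to compound 3 (0.12 log units; within the scatter).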

Compound 3, intrinsic clearance in a liver preparation (reported as CLH), per the amount of preparation that the assay uses: 14 uL/min
Compound 3: the middle estimate sits 1.4-fold (0.15 log units) above what was measured; measured number inside the range.
By their numbers in this assay, from the lowest: compounds 3, 2 and 1 (each within the scatter of the next).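

At this aromatic carbon, para to a large group, this assay hardly separates the substituents: trifluoromethyl in place of methylsulfonyl gives a 1.1-fold lower number from compound 2 to compound 3 (0.03 log units; within the scatter) and trifluoromethyl in place of 1H-pyrazol-1-yl gives a 1.3-fold lower number from compound 1 to compound 3 (0.12 log units; within the scatter) in the series. Trifluoromethyl, with 0 hydrogen-bond acceptors, and methylsulfonyl, with 2, therefore read alike here, and all three compounds lie within the scatter of one another. Nothing available accounts for this flat result.

On these data alone, whether an amine or a carboxylic acid on this carbon would stay within the same band remains open. So does whether a change elsewhere on the shared core would move the clearance.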